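The compounds below may be only part of what the source reports. "The series", "measured", "known", "first", "only" and "open" are said of these compounds alone.

Measured in a functional assay on NIH3T3 cells (Mus musculus) for cytotoxicity, read by MTT assay, with a stated time of 48 h; on this read-out higher numbers stand for weaker inhibition and lower numbers for stronger inhibition:
compound 1 `CC(=O)OC1=C(c2cc(C)nc3ccccc23)Oc2cc3ccccc3cc2-n2cccc21`: 278 nM
compound 2 `CCN(CC)C(=O)OC1=C(c2cc(C)nc3ccccc23)Oc2cc3ccccc3cc2-n2cccc21`: 9000 nM
compound 3 `CCc1cc(C2=C(OC(C)=O)c3cccn3-c3cc4ccccc4cc3O2)c2ccccc2n1`: 790 nM

Compound 1 has the lowest number of the three, which makes it the strongest inhibitor here. Compound 4 `CC(=O)OC1=C(c2cccc3cnccc23)Oc2cc3ccccc3cc2-n2cccc21` keeps the core of compound 1 and its acetoxy group but carries isoquinolin-5-yl in place of 2-methylquinolin-4-yl on a double-bonded ring carbon. The closest guide is compound 3, a small edit to that same group, with a 2.8-fold higher number from compound 1 to compound 3 (0.45 log units; beyond the scatter). The larger step at the carbonyl, a 32-fold higher number from compound 1 to compound 2 (1.51 log units; beyond the scatter), lies elsewhere and says little here. No whole-group swap has been measured, so only a modest rise is expected in this assay, a 2.7-fold higher number from compound 1 to compound 4 (0.43 log units; beyond the scatter). For compound 4 the estimated value is 750 nM, with an expected range of 200 nM to 3000 nM.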

Compound 4, half-maximal inhibitory concentration: 876 nM
Estimate against measurement, compound 4: 1.2-fold (0.07 log units) below; the range from low to high includes it.
By their numbers in this assay, from the lowest: compound 1; then compounds 3 and 4 (each within the scatter of the next); then compound 2.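

Swapping the whole 2-methylquinolin-4-yl group for isoquinolin-5-yl gives a 3.2-fold higher number from compound 1 to compound 4 (0.50 log units; beyond the scatter), so inhibition weakens only modestly even though the entire group changes, not just a small part of it. That places compound 4 within the scatter of compound 3, which differs from compound 1 by only one added methyl on this group. Nothing available explains this rise.

Open, from the compounds shown here alone, is whether an amine or a carboxylic acid on the quinoline would move the number further. Also open, going by these compounds, is how isoquinolin-5-yl behaves alongside the diethylamino carbonyl group of compound 2.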